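The compounds below may be only part of what the source reports. "The series", "measured", "known", "first", "only" and "open" are said of these compounds alone.

In a functional assay on the whole organism with Mus musculus as the target (on this read-out lower numbers stand for an effect already at smaller amounts and higher numbers for an effect only at larger amounts of compound), compound 1 `Cc1c(C)c2c(c(C)c1N)CC(C)(C)O2` gives 7.8 mg/kg. Compound 2 `CCC(=O)Nc1c(C)c(C)c2c(c1C)CC(C)(C)O2` has propanoyl in place of hydrogen on a nitrogen on an aromatic ring. Compound 2 stands at > 100 mg/kg, which is a limit of the assay and not a number. Compound 3 `CNc1c(C)c(C)c2c(c1C)CC(C)(C)O2` keeps the shared core and changes that same group: methyl in place of propanoyl on a nitrogen on an aromatic ring. In words, methyl takes the place of propanoyl. Going by the values given here, one measured step bears on this, the large at least 12-fold higher number from compound 1 to compound 2 (1.10 log units; beyond the scatter), which added the propanoyl on that nitrogen. Among the compounds with values here, removing the propanoyl can be expected to undo much of that step, although methyl is not hydrogen and no measured compound shows what methyl does there. A large move towards smaller doses is therefore expected in this assay. The expected size is an at least 8.3-fold lower number from compound 2 to compound 3 (0.92 log units; beyond the scatter). Compound 3 is estimated at 12 mg/kg, with an expected range from 3 mg/kg to 50 mg/kg.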

Compound 3, dose for 50% inhibition: 16.6 mg/kg
The estimate for compound 3 lay 1.4-fold (0.14 log units) below the measured number; the range from low to high includes it.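

Until now this nitrogen had carried only hydrogen or propanoyl, so any group placed there might have cost the effect in this assay. Methyl shows otherwise, with an at least 6.0-fold lower number from compound 2 to compound 3 (0.77 log units; beyond the scatter) when it replaces propanoyl, so the large loss belongs to propanoyl and not to every group on this nitrogen. Methyl still does not fully match hydrogen, with a 2.1-fold higher number from compound 1 to compound 3 (0.33 log units; beyond the scatter) as a modest cost that lies beyond the scatter.

From the compounds shown here alone, whether the loss follows the carbonyl or the length of the chain stays open, and an ethyl or an acetyl on this nitrogen would be needed to separate the two. Compound 2 stands at a limit of the assay and not a number, so the full size of its steps also stays open: the limit of > 100 mg/kg in this assay, at which 1 of the 3 values shown sits.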